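Anilino-substituted core series: from iodo to dimethyl aryl

This account rests on a few compounds, and the source may have more. Where it says the series, first, only, none or still open, it means among the compounds named here.

Compound 1 `O=C1C=C(Nc2ccc(I)cc2)C(=O)c2c1nc1n2[C@H]2OC[C@@H](O)[C@H]2OC1` gives 2300 nM in a functional assay on ECa-109 cells for inhibition, with ECa-109 cell line (Homo sapiens) as the target, read by sulforhodamine B assay; on this read-out higher numbers stand for weaker inhibition and lower numbers for stronger inhibition. Compound 2 `Cc1ccc(NC2=CC(=O)c3nc4n(c3C2=O)[C@H]2OC[C@@H](O)[C@H]2OC4)cc1` gives 3480 nM and compound 3 `COc1cccc(NC2=CC(=O)c3c(nc4n3[C@H]3OC[C@@H](O)[C@H]3OC4)C2=O)c1` gives 3340 nM; all three numbers lie within the scatter of one another, so compound 1 is not separated from either neighbour. The change to compound 4 `Cc1ccc(NC2=CC(=O)c3nc4n(c3C2=O)[C@H]2OC[C@@H](O)[C@H]2OC4)cc1C` is 3,4-dimethylphenyl in place of 4-iodophenyl on an amine nitrogen. For the measured compounds named here, the one measured step that bears on it is a 1.5-fold higher number from compound 1 to compound 2 (0.18 log units; within the scatter), the exchange of iodo for methyl on the same aromatic ring, and it stayed within the scatter. Going by the values given here, compound 4 carries that methyl plus a second one, and no measured pair shows what a second methyl does. The step is therefore expected to be small, a 1.4-fold higher number from compound 1 to compound 4 (0.16 log units; within the scatter), with no direction beyond the scatter. Compound 4 is estimated at 3300 nM, within 1500 nM to 7500 nM.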

Compound 4, half-maximal inhibitory concentration: 2820 nM
Beside the measured number, compound 4's estimate is 1.2-fold (0.07 log units) above it; low and high end bracket the measured number.
By their numbers in this assay, from the lowest: compounds 1, 4, 3 and 2 (each within the scatter of the next).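

In this assay, the exchange of 4-iodophenyl for 3,4-dimethylphenyl on the amine nitrogen stays small, a 1.2-fold higher number from compound 1 to compound 4 (0.09 log units; within the scatter). Adding the second methyl on the aromatic carbon is equally small, a 1.2-fold lower number from compound 2 to compound 4 (0.09 log units; within the scatter), so compound 1, compound 2 and compound 4 are not separated. Nothing available here gives a reason for this. The aryl groups shown carry only iodo, methyl or methoxy. On these data alone, whether a carboxylic acid or an amine on that ring, or a longer chain in place of the ring, would move the number beyond the scatter remains open.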